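This account rests on a few compounds, and the source may have more. Where it says the series, first, only, none or still open, it means among the compounds named here.

Compound 3 `CCC(C)(C)Cc1c[nH]c(CCc2ccc(-c3ccccc3OCc3nc(N)n[nH]3)cc2)n1` gives 78 nM in a functional assay for agonist activity at Bombesin receptor subtype-3 (Homo sapiens); on this read-out lower numbers stand for an effect already at smaller amounts and higher numbers for an effect only at larger amounts of compound. It stands together with compound 1 `c1ccc(-c2nnn[nH]2)c(-c2ccc(CCc3nc(CC4CCCC4)c[nH]3)cc2)c1` at 56 nM and compound 2 `CCC(C)(C)Cc1c[nH]c(CCc2ccc(-c3ccccc3OCC(=O)O)cc2)n1` at 54 nM; none of the three is separated from another beyond the scatter. Compound 4 `CCC(C)(C)Cc1c[nH]c(CCc2ccc(-c3ccccc3OCc3nc(=O)[nH][nH]3)cc2)n1` differs from compound 3 by a group of 6 heavy atoms (2 carbon, 3 nitrogen, 1 oxygen; one five-membered aromatic ring with 3 hetero atoms) in place of a group of 6 heavy atoms (2 carbon, 4 nitrogen; one five-membered aromatic ring with 3 hetero atoms), on a saturated chain carbon bound to an oxygen on an aromatic ring. Among the measured compounds shown here, the only measured step at this place, a 1.4-fold higher number from compound 2 to compound 3 (0.16 log units; within the scatter), exchanged one small acidic end for a five-membered ring without moving the number beyond the scatter. Compound 4 again swaps one such ring for another of the same size at the same place, so no step beyond the scatter is expected, a 1.0-fold higher number from compound 3 to compound 4 (0.01 log units; within the scatter). Compound 4 is therefore estimated at 80 nM, with a range from 35 nM to 180 nM.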

Compound 4, half-maximal effective concentration: 336 nM
Compound 4: the middle estimate sits 4.2-fold (0.62 log units) below what was measured, and the stated range ends below it.
By their numbers in this assay, from the lowest: compounds 2, 1 and 3 (each within the scatter of the next); then compound 4.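

In this assay, among the compounds shown here, this place on a saturated chain carbon bound to an oxygen on an aromatic ring does not treat all five-membered aromatic rings with 3 hetero atoms alike: exchanging the 3-amino-1H-1,2,4-triazol-5-yl for the ring of compound 4 gives a 4.3-fold higher number from compound 3 to compound 4 (0.63 log units; beyond the scatter), the first step here beyond the scatter. The carboxy group of compound 2 is also separated from this ring, with a 6.2-fold higher number from compound 2 to compound 4 (0.79 log units; beyond the scatter). Nothing available explains these steps. On these data alone, it remains open how a methylamino or hydroxyl group in place of the amino group on the ring would read.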